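Amide Variation on a Shared Core: the Step to Compound 4

This account rests on a few compounds, and the source may have more. Where it says the series, first, only, none or still open, it means among the compounds named here.

Across one shared core, the change runs on the amide-type nitrogen. Compound 1 `CNC(=O)CC1CCc2cc(OC)c(OC)cc21` gives, in a functional assay on the whole organism (strain Wistar) for inhibition, with Rattus norvegicus as the target, read by paw edema, with stated times of 60 min and 24 h, at a dose of 100 mg/kg by the oral route (on this read-out higher numbers stand for more inhibition at the one dose given (going by the name of the read-out) and lower numbers for less inhibition), 33.3%. Compound 2 `COc1cc2c(cc1OC)C(CC(=O)NC(C)(C)C)CC2`, with tert-butyl in place of methyl on an amide-type nitrogen, gives 40%, which is a number 6.7 percentage points higher from compound 1 to compound 2 (within the scatter). Compound 3 `CCCCCCNC(=O)CC1CCc2cc(OC)c(OC)cc21` gives 45.5%, with a number 12.2 percentage points higher from compound 1 to compound 3 (beyond the scatter) and a number 5.5 percentage points higher from compound 2 to compound 3 (within the scatter). Compound 3 thus stands highest of the three numbers, but beyond the scatter only against compound 1; against compound 2 the two values lie within the scatter, so no order between them is claimed.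

Compound 4 `COc1cc2c(cc1OC)C(CC(=O)N1CCCCC1)CC2` differs from compound 3 by piperidin-1-yl in place of hexylamino on a carbonyl carbon. Within the data shown here, the steps that bear on it are those on the amide-type nitrogen: a number 6.7 percentage points higher from compound 1 to compound 2 (within the scatter) and a number 5.5 percentage points higher from compound 2 to compound 3 (within the scatter) were both within the scatter, and only a number 12.2 percentage points higher from compound 1 to compound 3 (beyond the scatter) was beyond it, a modest size. A change that removes the hydrogen-bond donor and closes the chain into a six-membered non-aromatic ring has no measured parallel here. Compound 4 is therefore expected to show a number 1.5 percentage points lower from compound 3 to compound 4 (within the scatter), not beyond the scatter. Compound 4 is estimated at 44%, in the range 30% to 58%.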

Compound 4, a percentage reported as inhibition, in the whole organism at one dose (the size of the read-out at that dose, not a potency): 40%
For compound 4 the middle estimate is 4 percentage points above the measured one; low and high end bracket the measured number.
By their numbers in this assay, from the lowest: compounds 1, 2, 4 and 3 (each within the scatter of the next, the first and the last beyond it).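

In this assay, piperidin-1-yl on the carbonyl carbon gives a number 5.5 percentage points lower from compound 3 to compound 4 (within the scatter) and no change at the digits printed from compound 2 to compound 4 (within the scatter) and a number 6.7 percentage points higher from compound 1 to compound 4 (within the scatter), so this change separates compound 4 from none of the three earlier compounds. All three earlier compounds keep the amide hydrogen, and the new result shows that a group with a six-membered non-aromatic ring and no hydrogen-bond donor still reads within the scatter of each of them. No measurement available here explains this result.

From the compounds shown here alone, whether a different ring on the same carbonyl carbon, such as pyrrolidin-1-yl or morpholin-4-yl, would move the number beyond the scatter stays open. So does whether diethylamino, which carries two open chains and no amide hydrogen, would read differently from the closed ring of compound 4.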